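Compound 3 to its unsubstituted amine, compound 4

This account rests on a few compounds, and the source may have more. Where it says the series, first, only, none or still open, it means among the compounds named here.

Measured so far in a functional assay on HepG2 cells (Homo sapiens) for inhibition, read by MTT assay, with a stated time of 48 h; on this read-out lower numbers stand for stronger inhibition and higher numbers for weaker inhibition:
- compound 1 `CCOC(=O)C1=C(NN=C(C#N)C#N)Nc2[nH]nc(C)c2C1c1ccc(N(C)C)cc1` gives 13700 nM
- compound 2 `CCOC(=O)C1=C(N/C=N/c2ncc(-c3ccccc3)s2)Nc2[nH]nc(C)c2C1c1ccc(N(C)C)cc1` gives 9790 nM
- compound 3 `CCOC(=O)C1=C(N/N=C(/Cl)c2ccc([N+](=O)[O-])cc2)Nc2[nH]nc(C)c2C1c1ccc(N(C)C)cc1` gives 55500 nM

Compound 3 has the highest number of the three, and compound 1 and compound 2 both lie beyond the scatter below it. Compound 4 `CCOC(=O)C1=C(N)Nc2[nH]nc(C)c2C1c1ccc(N(C)C)cc1` differs from compound 3 by one change: a hydrogen atom in place of a group of 12 heavy atoms (7 carbon, 2 nitrogen, 2 oxygen, 1 chlorine; one six-membered aromatic ring of carbon only), on an amine nitrogen. That amine nitrogen has a double-bonded ring carbon as its other neighbour.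

For the measured compounds named here, one measured step bears on this change: a 4.1-fold higher number from compound 1 to compound 3 (0.61 log units; beyond the scatter). It is modest and lies beyond the scatter, with the larger group giving the higher number. Compound 2 goes against reading that step as a size trend, since it also carries a large group on that nitrogen and gives 9790 nM. Going by the values given here, no measured compound shows the bare hydrogen at this position, so the removal itself is untested.

A modest step toward a lower number is expected in this assay, of about the size of the one measured, with wide uncertainty. The expected step is a 2.8-fold lower number from compound 3 to compound 4 (0.44 log units; beyond the scatter). The estimate for compound 4 is 20000 nM, with an expected range from 7000 nM to 60000 nM.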

Compound 4, half-maximal inhibitory concentration: 4240 nM
For compound 4 the middle estimate is 4.7-fold (0.67 log units) above the measured one, and the stated range ends above it.
By their numbers in this assay, from the lowest: compound 4; then compounds 2 and 1 (each within the scatter of the next); then compound 3.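

In this assay, for the compounds shown here, compound 4 is the first compound to show hydrogen on this amine nitrogen, and both readable removals run toward a lower number: a 13-fold lower number from compound 3 to compound 4 (1.12 log units; beyond the scatter) and a 3.2-fold lower number from compound 1 to compound 4 (0.51 log units; beyond the scatter). Neither the group of 12 heavy atoms nor the group of 6 heavy atoms is therefore needed for the read-out, and the removal is large for the first group and modest for the second, so the outcome depends on which group leaves; compound 2, at 9790 nM, also carries a large group here and goes against reading this as a simple size trend. Nothing available explains why the bare amine gives the lower number.

From the compounds shown here alone, whether a small group on this nitrogen, such as a methyl or an acetyl, would keep the number of compound 4 or move it toward those of the larger groups remains open. All the compounds shown also keep the same ester and the same remaining core, so it is open whether this step would hold with a carboxylic acid in place of that ester.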